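The source may report more compounds than this note shows. Statements on the series, on what has been measured and on what is new or still open speak of the compounds shown alone.

Working notes on the series. Within the data shown here, compound 1 `O=S(=O)(/C=C/c1ccc(O)c(O)c1)Cc1ccccc1` gives 10.1 10^-6 cm/s in a physicochemical assay for permeability, using PAMPA, with a stated time of 18 h, tested at 5 mg/mL (on this read-out higher numbers stand for higher permeability and lower numbers for lower permeability), and stands highest of the three numbers measured so far. Compound 2 `O=S(=O)(/C=C/c1ccc(O)c(O)c1)CCc1ccccc1` gives 5.7 10^-6 cm/s in this assay, and compound 3 `O=S(=O)(/C=C/c1ccc(O)c(O)c1)CCCCc1ccccc1` gives 4.1 10^-6 cm/s in this assay. Among the measured compounds shown here, the only step between measured compounds that differ in a single place, a 1.8-fold lower number from compound 1 to compound 2 (0.25 log units; within the scatter), is within the scatter; the gap from compound 1 down to compound 3 is beyond it, so the number falls as the saturated chain on the sulfonyl sulfur lengthens from compound 1 through compound 2 to compound 3.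

Compound 4 `O=S(=O)(/C=C/c1ccc(O)c(O)c1)Cc1ccc(C(F)(F)F)cc1` differs from compound 1 by trifluoromethyl in place of hydrogen on an aromatic carbon. No measured step touches the aromatic ring of the benzyl group; the one step shown, a 1.8-fold lower number from compound 1 to compound 2 (0.25 log units; within the scatter), concerns chain length only and is itself within the scatter, so it gives no direct guide to this change. With nothing in the series pointing one way, the expectation for compound 4 is a step of a 1.1-fold lower number from compound 1 to compound 4 (0.03 log units; within the scatter), that is, no change beyond the scatter, with the range kept wide for lack of a bearing step. Compound 4 is therefore estimated at 9.5 10^-6 cm/s, with a range from 5 10^-6 cm/s to 18 10^-6 cm/s.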

Compound 4, apparent permeability: 4.3 10^-6 cm/s
The estimate for compound 4 lay 2.2-fold (0.34 log units) above the measured number; measured number outside the range, below it.
By their numbers in this assay, from the lowest: compounds 3, 4, 2 and 1 (each within the scatter of the next, the first and the last beyond it).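

In this assay, among these compounds, trifluoromethyl in place of hydrogen on an aromatic carbon, para to a large group, gives a 2.3-fold lower number from compound 1 to compound 4 (0.37 log units; beyond the scatter) and is modest in size, but it is the first step to touch the aromatic ring of the benzyl group. Unlike a 1.8-fold lower number from compound 1 to compound 2 (0.25 log units; within the scatter), which stays within the scatter, this single change lies beyond it, so the read-out does respond to a substitution at this ring position. The data at hand offer no measurement that would explain the lower number for compound 4.

With trifluoromethyl as the only group shown at this position, it remains open whether a fluorine, a methoxy group, an amine or a carboxylic acid on the same aromatic carbon would move the number in the same direction, by a similar amount or not at all. As far as these compounds go, it also remains open whether trifluoromethyl at this place would give a comparable step on the longer chains of compound 2 and compound 3.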